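The source may report more compounds than this note shows. Statements on the series, on what has been measured and on what is new or still open speak of the compounds shown alone.

Measured compounds and values in a functional assay on ME-180 cells (Homo sapiens) for cytotoxicity, read by MTT assay, with a stated time of 72 h; on this read-out lower numbers stand for stronger inhibition and higher numbers for weaker inhibition:
- compound 1 `COc1ccc(/C=C/C(=O)Nc2cc(C(=O)c3cc(OC)c(OC)c(OC)c3)ccc2OC)cc1`: 11800 nM
- compound 2 `COc1ccc(/C=C/C(=O)Nc2cc(C(=O)c3cc(OC)c(OC)c(OC)c3)cc(OC)c2OC)cc1`: 12500 nM
- compound 3 `C#CCOc1cccc(/C=C/C(=O)Nc2cc(C(=O)c3cc(OC)c(OC)c(OC)c3)cc(OC)c2OC)c1`: 8400 nM

Compound 2 carries the highest of the three numbers in this assay, but it sits within the scatter of both neighbours: a 1.1-fold higher number from compound 1 to compound 2 (0.03 log units; within the scatter) and a 1.5-fold lower number from compound 2 to compound 3 (0.17 log units; within the scatter) are both small steps, so no ordering among the three is established.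

Compound 4 `COc1cc(C(=O)c2cc(OC)c(OC)c(OC)c2)cc(N)c1OC` is not yet measured. It differs from compound 2 in one place: hydrogen in place of (2-(4-methoxyphenyl)ethenyl)carbonyl on a nitrogen on an aromatic ring. The fragment that leaves is the whole cinnamoyl-type group, so the amide is removed and the free amine remains.

Neither measured step bears on this change. The step from compound 1 to compound 2 concerns a methoxy on an aromatic carbon, and the step from compound 2 to compound 3 swaps one aryl group for another at the end of the chain; both left the number essentially unchanged. For the measured compounds named here, nothing among the measured pairs shows what removing the chain altogether does, so the direction of a 1.3-fold lower number from compound 2 to compound 4 (0.10 log units; within the scatter) is expected to be undetermined, and the estimate is kept broad.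

Compound 4 is therefore estimated at 10000 nM in this assay, with a range of 1500 nM to 50000 nM.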

Compound 4, half-maximal inhibitory concentration: 12200 nM
Compound 4: middle estimate off by 1.2-fold (0.09 log units), on the low side; measured number inside the range.
By their numbers in this assay, from the lowest: compounds 3, 1, 4 and 2 (each within the scatter of the next).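

In this assay, removing the whole (2-(4-methoxyphenyl)ethenyl)carbonyl from the nitrogen on an aromatic ring gives a 1.0-fold lower number from compound 2 to compound 4 (0.01 log units; within the scatter). The earlier steps shown here altered a methoxy or exchanged one aryl group for another at the end of the chain, whereas this one takes away the chain and its amide, with 12 heavy atoms leaving and only a hydrogen entering, and the two values still cannot be told apart. For this pair, the free amine of compound 4 and the amide of compound 2 therefore read alike on this assay, and no measurement at hand accounts for that result.

Open, from the compounds shown here alone, is whether any other group on this nitrogen, such as a short acetyl group, a longer saturated chain or a chain ending in a carboxylic acid, would give a number outside the scatter of these values. Also open, going by these compounds, is whether a change in the shared core, such as a hydroxyl in place of a methoxy on the trimethoxyphenyl ring, would separate any compound from this group.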